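The compounds below may be only part of what the source reports. "The series", "measured", "known", "first", "only" and "open" are said of these compounds alone.

Measured in a functional assay on MCF-10A cells (Homo sapiens) for antiproliferative activity, with a stated time of 48 h; on this read-out higher numbers stand for an effect only at larger amounts of compound and lower numbers for an effect already at smaller amounts:
Compound 1 `COc1ccc2nc(C)cc(NCc3cccnc3)c2c1`: 44800 nM
Compound 2 `COc1ccc2nc(C)cc(NCc3ccc(C(C)(C)C)cc3)c2c1`: 6900 nM

Compound 2 has the lower number of the two, with compound 1 standing above it by a gap beyond the scatter. Compound 3 `COc1ccc2nc(C)cc(NCc3ccc(N(C)C)cc3)c2c1` has not yet been measured. It differs from compound 2 in one place: dimethylamino in place of tert-butyl on an aromatic carbon, with dimethylamino in place of tert-butyl on an aromatic carbon. Going by the values given here, no measured pair shows a change in one place, so the data offer only weak guidance. In this assay, a small rise within the scatter is expected, an estimated 1.7-fold higher number from compound 2 to compound 3 (0.24 log units; within the scatter). For compound 3 the estimated value is 12000 nM, with an expected range of 4000 nM to 32000 nM.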

Compound 3, half-maximal effective concentration: 15100 nM
Compound 3: the middle estimate sits 1.3-fold (0.10 log units) below what was measured; low and high end bracket the measured number.
By their numbers in this assay, from the lowest: compound 2; then compound 3; then compound 1.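

In this assay, going by these compounds alone, the swap of tert-butyl for dimethylamino on an aromatic carbon gives a 2.2-fold higher number from compound 2 to compound 3 (0.34 log units; beyond the scatter), the first change in one place that can be read. It shows that the read-out responds to the group at this position, though only modestly for this exchange of a carbon-only group for one carrying a nitrogen. Nothing available explains the shift. From the compounds shown here alone, it remains open how a methoxy group, a chlorine atom or a carboxylic acid at this carbon would compare, and a single step sets no trend.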